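The source may hold more compounds than are shown below. What is called first, only, known or untested is meant among the compounds shown, and "the series" means these compounds.

Compounds measured in a functional assay on WiDr cells (Homo sapiens) for antiproliferative activity, read by sulforhodamine B assay, with a stated time of 48 h; on this read-out lower numbers stand for stronger inhibition of growth and higher numbers for weaker inhibition of growth:
compound 1 `Cc1ccc(S(=O)(=O)N2CCC(Cl)=CC2CC(C)C)cc1` gives 21000 nM.
compound 2 `Cc1ccc(S(=O)(=O)N2CC=C(Br)CC2)cc1` gives > 100000 nM, which is a limit of the assay and not a number.

Within the data shown here, compound 2 therefore stands at the top of the range that this assay reports, at the limit of > 100000 nM in this assay, at which 1 of the 2 values shown sits; of the two values shown it is the only one without a number. Among the measured compounds shown here, compound 1 is the only compound of the pair with a measured value, and it carries an isobutyl group that compound 2 lacks, together with chloro in place of bromo, so no single step between the two is counted.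

Compound 3 `Cc1ccc(S(=O)(=O)N2CCC(Br)=CC2CC(C)C)cc1` differs from compound 2 by isobutyl in place of hydrogen on a saturated ring carbon. For the measured compounds named here, no measured step of this kind exists. Compound 2 itself gives only a limit of the assay. Compound 1 is the closest measured analogue bearing the isobutyl group, and because in this assay compound 1 gives 21000 nM, the step is expected to go toward stronger inhibition of growth and to lie beyond the scatter, its size being uncertain: an at least 4.0-fold lower number from compound 2 to compound 3 (0.60 log units; beyond the scatter). Compound 3 is accordingly estimated at 25000 nM, within 8000 nM to 90000 nM.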

Compound 3, concentration for 50% growth inhibition: 16000 nM
For compound 3 the middle estimate is 1.6-fold (0.19 log units) above the measured one; measured number inside the range.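

In this assay, isobutyl in place of hydrogen on a saturated ring carbon, next to the ring nitrogen, gives an at least 6.2-fold lower number from compound 2 to compound 3 (0.79 log units; beyond the scatter), so with bromo held constant this position now has a direct step that goes toward stronger inhibition of growth. Bromo in place of chloro on a double-bonded ring carbon gives a 1.3-fold lower number from compound 1 to compound 3 (0.12 log units; within the scatter), so with the isobutyl group present, the two halogens cannot be told apart on this read-out. Compound 2 gives only a limit of the assay and not a number, which makes the isobutyl step a bound rather than a size: the limit of > 100000 nM in this assay, at which 1 of the 3 values shown sits.

The compounds shown leave open how the growth-inhibition number responds to a methyl group, a longer chain or a primary amine on this saturated ring carbon, and therefore whether the change follows chain length or is particular to isobutyl. From the compounds shown here alone, it also remains open whether bromo and chloro stay level on the shared core without the isobutyl group.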